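Compound 2 to compound 3: a carbonyl substituent swapped

The compounds below may be only part of what the source reports. "The series", "measured", "known", "first", "only" and "open" are said of these compounds alone.

Compound 1 `C=CC(=O)Nc1ncc(-c2ccccc2)s1` gives > 30000 nM in a functional assay on HCT-116 cells (Homo sapiens) for antiproliferative activity, read by MTT assay, with a stated time of 72 h (a higher number here means a weaker inhibitor, a lower number a stronger inhibitor), as a limit of the assay and not a number. Compound 2 `C=CC(=O)N(CC(=O)OC)c1nc(-c2ccccc2)cs1` gives > 30000 nM in this assay and is likewise known only as a limit. For the measured compounds named here, compound 1 and compound 2 together make up the limit of > 30000 nM in this assay, at which 2 of the 2 values shown sit, and no measured step joins them.

Compound 3 `C=CC(=O)N(CC(=O)NC1COC1)c1nc(-c2ccccc2)cs1` carries (oxetan-3-yl)amino in place of methoxy on a carbonyl carbon and otherwise keeps the core of compound 2. Going by the values given here, compound 2 stays at > 30000 nM as a limit, which leaves the expectation with no measured step to rest on. In this assay the expected change a number no higher from compound 2 to compound 3 (the limit leaves the size open) is no step beyond the scatter, with a modest gain in strength the only direction open to a reported number. Compound 3 is expected at 30000 nM with a range from 8000 nM to 60000 nM as estimated here.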

Compound 3, half-maximal inhibitory concentration: 20800 nM
For compound 3 the middle estimate is 1.4-fold (0.16 log units) above the measured one; low and high end bracket the measured number.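

In this assay, for the compounds shown here, compound 3 gives 20800 nM, the only value in this set that is a number and not a limit, so this place on the carbonyl carbon now has a measured reading. Compound 2 is known only as a limit: the limit of > 30000 nM in this assay, at which 2 of the 3 values shown sit. Placing (oxetan-3-yl)amino in place of methoxy gives an at least 1.4-fold lower number from compound 2 to compound 3 (0.15 log units; that floor lies within the scatter), so the change is not shown to exceed the scatter, and its true size remains unknown.

Whether the ring or the amide hydrogen accounts for the reported number stays open, since the change brings in both at once. Also open, from the compounds shown here alone, is how a carboxylic acid, a simple methylamino group or a longer chain on this carbonyl carbon would read in this assay.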